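The compounds below may be only part of what the source reports. "The series", "measured", "known", "first", "only" and "open" are said of these compounds alone.

Working notes on a small series in a functional assay on MT4 cells (Homo sapiens) for cytotoxicity; a lower number here means a stronger inhibitor, a higher number a weaker inhibitor. Compound 1 `Cc1cccc(S(=O)(=O)c2cccc(N)c2C#N)c1` gives 179000 nM. Compound 3 `N#Cc1c(N)cccc1S(=O)(=O)c1cccc(Cl)c1` reaches only the limit of the assay, > 200000 nM, which is a limit rather than a number. The change chloro in place of methyl on an aromatic carbon therefore gives an at least 1.1-fold higher number from compound 1 to compound 3 (0.04 log units; that floor lies within the scatter), a step read against (the limit of > 200000 nM in this assay, at which 2 of the 3 values shown sit). Compound 2 `Cc1ccc(S(=O)(=O)c2cccc(N)c2C#N)cc1` likewise sits at the limit, > 200000 nM, again a limit and not a number. Compound 2 and compound 1 hold the same atoms joined differently; the difference between the two cores is not broken down here.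

Compound 4 `N#Cc1c(N)cccc1S(=O)(=O)c1ccc(Cl)cc1` is not yet measured in this assay. It arises from compound 2 by chloro in place of methyl on an aromatic carbon. Among the compounds with values here, that is the same kind of change as the one from compound 1 to compound 3, though the place differs: here it is para to a large group, there meta to a large group. Given an at least 1.1-fold higher number from compound 1 to compound 3 (0.04 log units; that floor lies within the scatter), the step expected here is a step that the limit leaves unreadable from compound 2 to compound 4. Compound 4 is estimated at 250000 nM, between 120000 nM and 600000 nM, most probably reported only as a limit.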

Compound 4, half-maximal inhibitory concentration: > 5000 nM
Compound 4 was reported as a limit; the forecaster's own chance of this, stated with the estimate: 75%; the middle value does not contradict the limit.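

In this assay compound 4 gives > 5000 nM, which is a limit and not a number. Within the data shown here, compound 2 also stands only at a limit, so no step from compound 2 to compound 4 can be read. The compounds shown leave open whether chloro in place of methyl, para to a large group, changes the number at all.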